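A few compounds are considered here, and "the series" means these few. Any claim that something is new, unique, unknown or untested is made for them only; others in the source may bear on it.

Measured compounds:
compound 1 `OC1CCCN(c2nc(-c3ccccn3)nc3c2CN(Cc2ccccc2)CC3)C1`: in an assay on A549 cells with Cystic fibrosis transmembrane conductance regulator variant F508del (Homo sapiens) as the target, read by fluorescence, with a stated time of 25 min (a lower number here means a smaller maximal response, a higher number a larger maximal response), compound 1 gives 30.6%
compound 2 `NC(=O)C1CCN(c2nc(-c3ccccn3)nc3c2CN(Cc2ccccc2)CC3)CC1`: compound 2 gives 34.4%
compound 3 `CN1CCN(CCCNc2nc(-c3ccccn3)nc3c2CN(Cc2ccccc2)CC3)CC1`: compound 3 is reported as "not active" (no number reported)

Compound 2 and compound 1 lie within the scatter of each other, the step of a number 3.8 percentage points higher from compound 1 to compound 2 (within the scatter) being too small to read as a change; compound 3 gives no number. Compound 4 `NC(=O)C1CCN(c2nc(-c3cccnc3)nc3c2CN(Cc2ccccc2)CC3)CC1` differs from compound 2 only in the change (pyridin-3-yl in place of pyridin-2-yl on an aromatic carbon). Within the data shown here, no measured step covers this swap: the one step available, from compound 1 to compound 2, concerns the piperidine substituent and says nothing about the pyridine. An expectation for compound 4 therefore rests on compound 2 alone, and the step of a number 4.4 percentage points lower from compound 2 to compound 4 (within the scatter) is estimated as small, without a direction the data can support. Compound 4 is expected to give 30%, within 12% to 46%.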

Compound 4, largest response reached (Emax), in percent of the reference or control that the assay uses: "not active" (no number reported)
No number was reported for compound 4; the estimate stays without a comparison.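

Among these compounds, compound 4 is reported without a number, so no step from compound 2 to compound 4 can be read in this assay. Nothing shown bears on this result. The compounds shown leave open how far pyridin-3-yl in place of pyridin-2-yl alters the response.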